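The source may report more compounds than this note shows. Statements on the series, on what has been measured and on what is new or still open speak of the compounds shown alone.

- compound 1 `O=C(Nc1ccccc1)Nc1cccc(Nc2nccc(Nc3ccc4nc[nH]c4c3)n2)c1`: 11000 nM
- compound 2 `O=C1NC(Cc2ccc(Nc3nccc(Nc4ccc5cn[nH]c5c4)n3)cc2)CO1`: 20000 nM

In a functional assay on HepG2 cells (Homo sapiens) for inhibition, read by fluorescence and resazurin assay, with a stated time of 72 h (a lower number here means a stronger inhibitor, a higher number a weaker inhibitor), compound 1 gives 11000 nM and compound 2 gives 20000 nM. These two numbers lie within the usual scatter of each other, so compound 1 shares its place with compound 2 and no order can be drawn between them.

Compound 3 `O=C(Nc1ccccc1)Nc1cccc(Nc2nccc(Nc3ccc4[nH]ncc4c3)n2)c1` keeps the rest of compound 1 and changes one group: 1H-indazol-5-yl in place of 1H-benzimidazol-6-yl on a nitrogen on an aromatic ring. It carries 1H-indazol-5-yl in place of 1H-benzimidazol-6-yl on a nitrogen on an aromatic ring. The two groups hold the same atoms, joined differently.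

Among the compounds with values here, no two measured compounds differ in only one place, so the data give no direct measure of this swap. Within the data shown here, the only guide is that compound 1 at 11000 nM and compound 2 at 20000 nM sit close together despite their different structures. In this assay, no step beyond the scatter is therefore expected. The estimated step is a 1.1-fold higher number from compound 1 to compound 3 (0.04 log units; within the scatter). The expected value for compound 3 is 12000 nM, with an estimated range of 4500 nM to 30000 nM.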

Compound 3, half-maximal inhibitory concentration: 8100 nM
Beside the measured number, compound 3's estimate is 1.5-fold (0.17 log units) above it; the range from low to high includes it.
By their numbers in this assay, from the lowest: compounds 3, 1 and 2 (each within the scatter of the next, the first and the last beyond it).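

In this assay, within the data shown here, putting 1H-indazol-5-yl in place of 1H-benzimidazol-6-yl gives a 1.4-fold lower number from compound 1 to compound 3 (0.13 log units; within the scatter) and is the first direct measure of a change at this place, on a nitrogen on an aromatic ring. Among these compounds, the two groups have the same atoms and the same counts of hydrogen-bond donors and acceptors, and joining those atoms differently produces no step that can be told apart from the scatter, so this pair of compounds does not separate the two groups. No measurement shown here bears on what lies behind this result.

Because both groups have the same kind of two-ring shape, the compounds shown leave open how this place responds to a real change in the group, such as a single pyridin-3-yl ring or a chain ending in an amine or a carboxylic acid. They also leave open whether any group at this place can produce a step beyond the scatter, since this one swap covers only a small part of what could be placed there.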